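Swapping Cyclohexyl for 4-Methylphenyl on a Second Core

This account rests on a few compounds, and the source may have more. Where it says the series, first, only, none or still open, it means among the compounds named here.

Three sulfonamide-bearing compounds have been tested in a functional assay on HeLa cells (Homo sapiens) for antiproliferative activity, read by MTT assay, with a stated time of 72 h; a lower number here means a stronger inhibitor, a higher number a weaker inhibitor. Compound 1 `O=C1COc2ccc(-c3cnc(Cl)c(NS(=O)(=O)c4ccc(F)cc4)c3)cc2N1C1CCCCC1` gives 14300 nM. Compound 2 `Cc1ccc(N2C(=O)COc3ccc(-c4cnc(Cl)c(NS(=O)(=O)c5ccc(F)cc5)c4)cc32)cc1` carries 4-methylphenyl in place of cyclohexyl on an amide-type nitrogen in a ring, and in this assay compound 2 gives 32300 nM; this change made a 2.3-fold higher number from compound 1 to compound 2 (0.35 log units; beyond the scatter). Compound 3 `O=C1COc2ccc(-c3cccc(NS(=O)(=O)c4ccc(F)cc4)c3)cc2N1C1CCCCC1` rests on another core; the difference between the two cores is not broken down here. In this assay compound 3 gives 10800 nM, a number within the scatter of compound 1 and beyond the scatter from compound 2.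

Compound 4 `Cc1ccc(N2C(=O)COc3ccc(-c4cccc(NS(=O)(=O)c5ccc(F)cc5)c4)cc32)cc1` has not yet been measured. It stands to compound 3 as compound 2 stands to compound 1: 4-methylphenyl in place of cyclohexyl on an amide-type nitrogen in a ring. The place of the change is the same word for word in both pairs, so it is the same change made on a second core. The step is expected to repeat in size because a 2.3-fold higher number from compound 1 to compound 2 (0.35 log units; beyond the scatter) was measured on a core whose value lies within the scatter of compound 3. The estimated step is a 2.3-fold higher number from compound 3 to compound 4 (0.36 log units; beyond the scatter). Compound 4 is therefore expected to give about 25000 nM, most likely between 12000 nM and 50000 nM.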

Compound 4, half-maximal inhibitory concentration: > 40000 nM
Compound 4: only a limit was reported; the forecaster's own chance of this, stated with the estimate: 10%; middle value at least 1.6-fold (0.20 log units) away from the limit.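

In this assay compound 4 gives > 40000 nM, which is a limit of the assay and not an exact number. Putting 4-methylphenyl in place of cyclohexyl on the amide-type nitrogen gave an at least 3.7-fold higher number from compound 3 to compound 4 (0.56 log units; beyond the scatter), so the change moved the number in the same direction on both cores, towards a weaker inhibitor. This does not show that the change carries over with the same size, and two cores are too few to make a general rule for the series: the same change on two cores in this assay, a 2.3-fold higher number (0.35 log units; beyond the scatter) from compound 1 to compound 2 and an at least 3.7-fold higher number (0.56 log units; beyond the scatter) from compound 3 to compound 4; the limit leaves it open whether they differ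

The compounds shown hold only cyclohexyl and 4-methylphenyl on that nitrogen, so it stays open how a methyl, a longer chain, or a phenyl ring carrying an amine or a carboxylic acid would behave on either core. Also open, from the compounds shown here alone, is the true size of the step on the second core, which only an exact number for compound 4 could settle.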